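A few compounds are considered here, and "the series" means these few. Any claim that something is new, unique, unknown or untested is made for them only; others in the source may bear on it.

In a functional assay on CHO cells for antagonist activity at Orexin/Hypocretin receptor type 1 (Homo sapiens), read by FLIPR and calcium flux; a higher number here means a more potent compound, by a factor of ten per unit of this negative logarithm, a lower number a less potent compound: compound 1 `O=C(c1cc(Cl)ccc1-c1ncccn1)N1CC2(CC2)C[C@H]1CNc1cc(C(F)(F)F)ccn1` gives 8.1; compound 2 `O=C(c1cc(Cl)ccc1-c1ncccn1)N1CC2(CC2)C[C@H]1CNc1ccc(C(F)(F)F)cn1` gives 8.1; compound 3 `Cc1cc(C)nc(NC[C@@H]2CC3(CC3)CN2C(=O)c2nc(C)sc2-c2ccccc2)n1` gives 7.5.

Compound 2 stands level with compound 1 at the digits shown, the two together the highest of the three numbers; compound 3 sits lower, beyond the scatter. The next compound, compound 4 `Cc1ccc(-c2ncccn2)c(C(=O)N2CC3(CC3)C[C@H]2CNc2ccc(C(F)(F)F)cn2)c1`, differs from compound 2 by methyl in place of chloro on an aromatic carbon. Within the data shown here, the only measured step, no change at the digits printed from compound 1 to compound 2 (within the scatter), moves the trifluoromethyl on the pyridine and says nothing about the aromatic carbon carrying the chloro; no measured pair in this set bears on methyl in place of chloro. The expectation is therefore a step of a number 0.10 log units lower from compound 2 to compound 4 (within the scatter), within the scatter. The estimate for compound 4 is 8, expected between 7.5 and 8.5.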

Compound 4, negative logarithm of the antagonist equilibrium constant: 8.7
Compound 4: middle estimate off by 0.70 log units, on the low side; the measured number lies above the stated range.
By their numbers in this assay, from the lowest: compound 3; then compounds 1 and 2 (each within the scatter of the next); then compound 4.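

On an aromatic carbon para to a pyrimidin-2-yl group, a one-atom exchange moves the number beyond the scatter in this assay: methyl in place of chloro gives a number 0.60 log units higher from compound 2 to compound 4 (beyond the scatter). Among these compounds, this is the first single change to do so, and it shows that chloro is not required at this position for the number to hold or rise. Nothing measured here accounts for the gain.

From the compounds shown here alone, whether the gain is particular to methyl stays open, and ethyl, methoxy or fluoro at this carbon would test that. Also open, going by these compounds, is whether methyl gives the same step alongside the 4-(trifluoromethyl)pyridin-2-yl group of compound 1.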